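The source may report more compounds than this note shows. Statements on the series, on what has been measured and on what is new or still open speak of the compounds shown alone.

Measured compounds in a functional assay on MCF7 cells (Homo sapiens) for antiproliferative activity, read by MTT assay, with a stated time of 24 h; a higher number here means a weaker inhibitor, a lower number a stronger inhibitor:
compound 1 `CSc1nnc(COc2cc(C)c3c(C)cc(=O)oc3c2)o1` gives > 100000 nM, a limit of the assay.
compound 2 `CCCCSc1nnc(COc2cc(C)c3c(C)cc(=O)oc3c2)o1` gives > 100000 nM, a limit of the assay.
compound 3 `Cc1cc(OCc2nnc(SCc3ccccc3)o2)cc2oc(=O)cc(C)c12` gives > 100000 nM, a limit of the assay.

Compound 3 stands only at a limit, and the two other values shown are limits as well, so no order among the three can be read (the limit of > 100000 nM in this assay, at which 3 of the 3 values shown sit). The steps a step that the two limits leave unreadable from compound 1 to compound 2, a step that the two limits leave unreadable from compound 1 to compound 3 and a step that the two limits leave unreadable from compound 2 to compound 3 are accordingly of unreadable size. Compound 4 `Cc1cc(OCc2nnc(SCc3ccc(Cl)cc3Cl)o2)cc2oc(=O)cc(C)c12` differs from compound 3 by 2,4-dichlorophenyl in place of phenyl on a saturated chain carbon bound to a sulfur. For the measured compounds named here, since none of the measured steps has a readable size, no direction beyond the scatter is expected; compound 4 is expected to sit again at the limit, with a number no higher from compound 3 to compound 4 (the limit leaves the size open) estimated as no more than scatter. The estimate for compound 4 in this assay is 100000 nM, range 30000 nM to 300000 nM.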

Compound 4, half-maximal inhibitory concentration: < 5000 nM
Compound 4 gave a limit, no number; the forecaster's own chance of this, stated with the estimate: 75%; middle value at least 20-fold (1.30 log units) from the limit.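

In this assay, this place on a saturated chain carbon bound to a sulfur now gives a readable change: 2,4-dichlorophenyl in place of phenyl gives an at least 20-fold lower number from compound 3 to compound 4 (1.30 log units; beyond the scatter). The same group gives an at least 20-fold lower number from compound 2 to compound 4 (1.30 log units; beyond the scatter) in place of propyl, and an at least 20-fold lower number from compound 1 to compound 4 (1.30 log units; beyond the scatter) in place of hydrogen, so the change is large against all three earlier groups. Compound 4 gives < 5000 nM, which is a limit and not a number.

The steps among compound 1, compound 2 and compound 3 cannot be read. Going by these compounds, whether a single chlorine, a methoxy group or an amine on the phenyl would give a comparable step stays open.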